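The source may hold more compounds than are shown below. What is called first, only, known or untested is meant among the compounds shown, and "the series" means these compounds.

Compound 1 `COc1cc2c(cc1OC)C(/C(C)=N/NC(N)=S)N(S(=O)(=O)c1ccc([N+](=O)[O-])cc1)CC2`: > 50 ug/mL in a functional assay on HuCC-A1 cells (Homo sapiens) for cytotoxicity, read by crystal violet staining, with a stated time of 3 days (a lower number here means a stronger inhibitor, a higher number a weaker inhibitor), a limit of the assay.
Compound 2 `C/C(=N\NC(N)=S)C1c2ccccc2CCN1S(=O)(=O)c1ccc(C)cc1`: > 50 ug/mL in this assay, likewise a limit.

Compound 2 therefore stands at the limit, where both measured values sit (the limit of > 50 ug/mL in this assay, at which 2 of the 2 values shown sit), and no number separates it from compound 1. Compound 3 `C/C(=N\NC(N)=S)C1c2ccccc2CCN1S(=O)(=O)c1ccc([N+](=O)[O-])cc1` carries the change (nitro in place of methyl on an aromatic carbon), nitro in place of methyl on an aromatic carbon. With both measured compounds at the limit, no step beyond the scatter is expected from compound 2 to compound 3, and the expected step that the limit leaves unreadable from compound 2 to compound 3 is a small one. Compound 3 is expected at about 80 ug/mL, between 30 ug/mL and 200 ug/mL, most likely again reported as a limit.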

Compound 3, half-maximal inhibitory concentration: > 50 ug/mL
Compound 3: no number, only a limit; the forecaster's own chance of this, stated with the estimate: 85%; the middle value is on the limit's open side.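

No step can be read from compound 2 to compound 3, because both values are limits: the limit of > 50 ug/mL in this assay, at which 3 of the 3 values shown sit.

The compounds shown leave open how strong any of them is in this assay, and whether nitro in place of methyl on an aromatic carbon changes anything there.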